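A few compounds are considered here, and "the series" means these few. Any claim that something is new, unique, unknown or untested is made for them only; others in the source may bear on it.

In a functional assay on MDA-MB-231 cells (Homo sapiens) for antiproliferative activity, read by MTT assay, with a stated time of 24 h (a lower number here means a stronger inhibitor, a higher number a weaker inhibitor), compound 1 `COc1ccc(-c2noc(-c3ccncc3)n2)cc1OC1CCCC1` gives 240000 nM, compound 2 `COc1ccc(-c2noc(C3CCCN3)n2)cc1OC1CCCC1` gives 212000 nM and compound 3 `COc1ccc(-c2noc(C3CCNCC3)n2)cc1OC1CCCC1` gives 370 nM, the lowest number of the three. Compound 4 `COc1ccc(-c2noc(-c3ccc(F)cc3)n2)cc1OC1CCCC1` has not yet been measured. It carries 4-fluorophenyl in place of piperidin-4-yl on an aromatic carbon of the five-membered aromatic ring: 4-fluorophenyl in place of piperidin-4-yl on an aromatic carbon.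

The closest evidence is the exchange of pyridin-4-yl for piperidin-4-yl, a 650-fold lower number from compound 1 to compound 3 (2.81 log units; beyond the scatter). The exchange of pyrrolidin-2-yl for piperidin-4-yl, a 570-fold lower number from compound 2 to compound 3 (2.76 log units; beyond the scatter), was similar in size, while a 1.1-fold lower number from compound 1 to compound 2 (0.05 log units; within the scatter) stayed within the scatter. Piperidin-4-yl is thus the only group here linked to a low number, and compound 2 shows that a non-aromatic group does not guarantee one. For the measured compounds named here, no fluorophenyl compound has been measured, so compound 1, the only aromatic example at 240000 nM, is the nearest guide. A large move to a higher number is expected, a 160-fold higher number from compound 3 to compound 4 (2.21 log units; beyond the scatter). For compound 4 the estimated value is 60000 nM, with an expected range of 4000 nM to 300000 nM.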

Compound 4, half-maximal inhibitory concentration: 55500 nM
For compound 4 the middle estimate is 1.1-fold (0.03 log units) above the measured one; the measured number falls inside the stated range.
By their numbers in this assay, from the lowest: compound 3; then compound 4; then compounds 2 and 1 (each within the scatter of the next).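

In this assay, the step of a 150-fold higher number from compound 3 to compound 4 (2.18 log units; beyond the scatter) is large, so the low number at this position is lost with 4-fluorophenyl, an aromatic ring of carbon only, and not only with the pyridin-4-yl of compound 1. The other two steps, a 3.8-fold lower number from compound 2 to compound 4 (0.58 log units; beyond the scatter) and a 4.3-fold lower number from compound 1 to compound 4 (0.64 log units; beyond the scatter), are modest but beyond the scatter, so the groups that lack piperidin-4-yl are not all equal here, although all of them remain far from compound 3. No measurement shown gives a reason for either the large step or the modest ones.

As far as these compounds go, it remains open whether piperidin-3-yl or an open-chain amine such as aminomethyl would keep a number close to that of compound 3. Plain phenyl would be needed to tell what share of the modest steps belongs to the fluorine.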